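This account rests on a few compounds, and the source may have more. Where it says the series, first, only, none or still open, it means among the compounds named here.

Working notes on the series. In an ADME assay on NIH3T3 cells (Mus musculus) for cytotoxicity, read by CCK-8 assay, with a stated time of 24 h (on this read-out lower numbers stand for stronger inhibition and higher numbers for weaker inhibition), compound 3 `C/C(=C\c1cc(-c2ccc(C)cc2)cs1)C(N)=O` reaches only the limit of the assay, > 50000 nM. Compound 1 `C/C(=C\c1cc(-c2ccc(C)cc2)co1)C(N)=O` likewise stops at the limit, > 50000 nM. Compound 2 `C/C(=C\c1cc(-c2ccc(F)cc2)co1)C(N)=O` also stops at the limit, > 50000 nM. Among the measured compounds shown here, the only single-point step, a step that the two limits leave unreadable from compound 1 to compound 2, is accordingly unreadable because of the limit of > 50000 nM in this assay, at which 3 of the 3 values shown sit. Compound 4 `C=Cc1ccc(-c2csc(/C=C(\C)C(N)=O)c2)cc1` differs from compound 3 by vinyl in place of methyl on an aromatic carbon. For the measured compounds named here, no measured step bears directly on this change, and the one step that exists gives no readable size, so in this assay no shift beyond the scatter is expected and the limit is likely to be reached again. Compound 4 is expected to give about 60000 nM, within a range from 20000 nM to 200000 nM. The step that the limit leaves unreadable from compound 3 to compound 4 is thus estimated as essentially flat.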

Compound 4, half-maximal inhibitory concentration: > 50000 nM
Compound 4 ended at the assay's limit (the forecaster's own chance of this, stated with the estimate: 85%); the middle value does not contradict the limit.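

No step can be read from compound 3 to compound 4, because both stop at the limit of the assay: the limit of > 50000 nM in this assay, at which 4 of the 4 values shown sit.

The compounds shown leave open whether vinyl in place of methyl changes the read-out at all.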